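Dipropylamino to dimethylamino: working notes on the series

The compounds below may be only part of what the source reports. "The series", "measured", "known", "first", "only" and "open" are said of these compounds alone.

Measured in an ADME assay on HepG2 cells (Homo sapiens) for cytotoxicity; on this read-out lower numbers stand for higher toxicity in this test and higher numbers for lower toxicity in this test:
- compound 1 `CCOC(=O)CN(C)CC#Cc1cc2c(Nc3ccc(OCc4cccc(F)c4)c(Cl)c3)ncnc2s1`: > 28 uM (a limit of the assay, not a number)
- compound 2 `CCCN(CC#Cc1cc2c(Nc3ccc(OCc4cccc(F)c4)c(Cl)c3)ncnc2s1)CCC`: 17 uM

Going by the values given here, compound 2 (17 uM) holds the only actual number in this assay so far, so it has no rank. Compound 1 rests on a limit only. Compound 3 `CN(C)CC#Cc1cc2c(Nc3ccc(OCc4cccc(F)c4)c(Cl)c3)ncnc2s1` differs from compound 2 by dimethylamino in place of dipropylamino on a saturated chain carbon bound to a triple-bonded carbon and so carries dimethylamino in place of dipropylamino on a saturated chain carbon bound to a triple-bonded carbon. Among the compounds with values here, the one measured step bearing on this is an at least 1.6-fold lower number from compound 1 to compound 2 (0.21 log units; that floor lies within the scatter) and it brought dipropylamino in at that same place. That step gives only a floor, so it fixes no firm size here. A small rise is the most that is expected in this assay and no move beyond the scatter is likely. The estimated step is a 1.2-fold higher number from compound 2 to compound 3 (0.07 log units; within the scatter) and it would stay within the scatter. For compound 3 the expected value is 20 uM with an estimated range (9 uM to 40 uM).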

Compound 3, half-maximal toxic concentration: > 32 uM
Compound 3: no number, only a limit; the forecaster's own chance of this, stated with the estimate: 25%; at least 1.6-fold (0.20 log units) between middle value and limit.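

In this assay, dimethylamino in place of dipropylamino on a saturated chain carbon bound to a triple-bonded carbon gives an at least 1.8-fold higher number from compound 2 to compound 3 (0.27 log units; that floor lies within the scatter). Compound 3 gives > 32 uM, which is a limit of the assay and not a number, so this change has only a floor and no firm size: the limit of > 32 uM in this assay, at which 1 of the 3 values shown sits. Of the three compounds, compound 2 alone gives an actual number, while compound 1 and compound 3 both rest on limits, and the step joining those two cannot be read.

On these data alone, it remains open how far the true value of compound 3 lies from its limit. Also open, as far as these compounds go, is where diethylamino, morpholine or a longer chain on the amine nitrogen would fall in this assay, and whether any of them would give an actual number.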